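Chain extension on the amide of compound 2

A few compounds are considered here, and "the series" means these few. Any claim that something is new, unique, unknown or untested is made for them only; others in the source may bear on it.

Measured so far in an in vitro assay on HEK-293T cells for antagonist activity at transient receptor potential cation channel subfamily V member 1 (Rattus norvegicus), read by fluorescence and calcium flux, with a stated time of 30 min; on this read-out higher numbers stand for weaker inhibition and lower numbers for stronger inhibition:
Compound 1 `CCCCCC(=O)Nc1nnc(-c2cc(I)c(O)c(OC)c2)s1` gives 1.47 nM.
Compound 2 `CCCCCCCC(=O)Nc1nnc(-c2ccc(O)c(OC)c2)s1` gives 0.15 nM.
Compound 3 `CCCCCCC(=O)Nc1nnc(-c2cc(I)c(O)c(OC)c2)s1` gives 6.07 nM.

Compound 2 shows the lowest number of the three in this assay, with compound 1 nearest and compound 3 furthest, both gaps beyond the scatter. Compound 4 `CCCCCCCCC(=O)Nc1nnc(-c2ccc(O)c(OC)c2)s1` differs from compound 2 by methyl in place of hydrogen on a saturated chain carbon, seven bonds along the chain from a carbonyl carbon. Going by the values given here, the one measured step of the same kind is a 4.1-fold higher number from compound 1 to compound 3 (0.62 log units; beyond the scatter), made in a pair whose shared core otherwise differs from that of compound 2, and five bonds along the chain from a carbonyl carbon rather than seven. On that basis a modest rise in the number, toward weaker inhibition, is expected for compound 4, possibly smaller than in the measured pair. Compound 4 is expected to give about 0.35 nM, within 0.12 nM to 1.2 nM. That estimate means a step of a 2.3-fold higher number from compound 2 to compound 4 (0.37 log units; beyond the scatter).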

Compound 4, half-maximal inhibitory concentration: 0.18 nM
Estimate against measurement, compound 4: 1.9-fold (0.29 log units) above; the measured number falls inside the stated range.
By their numbers in this assay, from the lowest: compounds 2 and 4 (each within the scatter of the next); then compound 1; then compound 3.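

On the core of compound 2, methyl in place of hydrogen on a saturated chain carbon, seven bonds along the chain from a carbonyl carbon, is tolerated in this assay, with a 1.2-fold higher number from compound 2 to compound 4 (0.08 log units; within the scatter). The same change therefore does not give one step size across the two settings, although core and place differ together and cannot be separated here: the same change on two cores in this assay, a 4.1-fold higher number (0.62 log units; beyond the scatter) from compound 1 to compound 3 and a 1.2-fold higher number (0.08 log units; within the scatter) from compound 2 to compound 4, 3.4-fold (0.54 log units) apart, beyond the scatter of two such steps

Going by these compounds, whether a longer chain than that of compound 4 holds the number at this level remains open. So does the effect of an amine or a carboxylic acid in place of the entering methyl.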